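Swapping a ring amine for a propoxy chain

The compounds below may be only part of what the source reports. "The series", "measured", "known", "first", "only" and "open" are said of these compounds alone.

Compound 1, `CC(C(=O)NCc1ccc(C(F)(F)F)cc1N1CCCCCC1)c1ccc(NS(C)(=O)=O)c(F)c1`, gives 1.6 nM in an assay on CHO cells for antagonist activity at transient receptor potential cation channel subfamily V member 1 (Homo sapiens), read by FLIPR; on this read-out lower numbers stand for stronger inhibition and higher numbers for weaker inhibition.
Compound 2, `CCC1CCN(c2cc(C(F)(F)F)ccc2CNC(=O)C(C)c2ccc(NS(C)(=O)=O)c(F)c2)CC1`, gives 0.7 nM in this assay.
Compound 3, `CC(C(=O)NCc1ccc(C(F)(F)F)cc1N1CCC(C)(C)CC1)c1ccc(NS(C)(=O)=O)c(F)c1`, gives 1.3 nM in this assay.

Among these three numbers, compound 3 sits second highest. Its nearest neighbour is compound 1, with a 1.2-fold lower number from compound 1 to compound 3 (0.09 log units; within the scatter), and its furthest is compound 2, with a 1.9-fold higher number from compound 2 to compound 3 (0.27 log units; within the scatter); so all three compounds lie close together, and none can be called stronger or weaker than another on these data.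

The next compound, compound 4, `CCCOc1cc(C(F)(F)F)ccc1CNC(=O)C(C)c1ccc(NS(C)(=O)=O)c(F)c1`, carries the change (propoxy in place of 4,4-dimethylpiperidin-1-yl on an aromatic carbon). The three measured steps each exchange one saturated ring amine for another, and they stayed small: a 2.3-fold lower number from compound 1 to compound 2 (0.36 log units; beyond the scatter) was the largest, while a 1.2-fold lower number from compound 1 to compound 3 (0.09 log units; within the scatter) and a 1.9-fold higher number from compound 2 to compound 3 (0.27 log units; within the scatter) were within the scatter. None of them replaces the ring by an open chain attached through oxygen, so the present change goes further than anything measured here. The expectation is therefore a mild shift in this assay, most likely to a somewhat higher number, expressed as a 2.3-fold higher number from compound 3 to compound 4 (0.36 log units; beyond the scatter). On that basis compound 4 is estimated at 3 nM, within a range from 1 nM to 12 nM.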

Compound 4, inhibition constant: 2 nM
Compound 4: middle estimate off by 1.5-fold (0.18 log units), on the high side; measured number inside the range.
By their numbers in this assay, from the lowest: compounds 2, 3, 1 and 4 (each within the scatter of the next, the first and the last beyond it).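

In this assay, the place on the aromatic carbon meta to the trifluoromethyl group turns out to tolerate the loss of the ring amine altogether: propoxy has no ring and 4 heavy atoms against the 8 of 4,4-dimethylpiperidin-1-yl, and yet the data show a 1.5-fold higher number from compound 3 to compound 4 (0.19 log units; within the scatter) and a 1.3-fold higher number from compound 1 to compound 4 (0.10 log units; within the scatter) as steps that cannot be told from repeat-measurement noise. For the compounds shown here, only the step away from 4-ethylpiperidin-1-yl stands out, with a 2.9-fold higher number from compound 2 to compound 4 (0.46 log units; beyond the scatter) as a modest change, so the tolerance for propoxy holds against two of the three ring amines and not against this one. The data shown offer no evidence on what lies behind these small differences.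

Still open, as far as these compounds go, is whether the oxygen attached to the aromatic carbon or the length of the chain counts for more at this place. A butoxy chain, or a propylamino group with nitrogen as the attached atom, would help separate those two influences in this assay and show how far an open chain can vary here.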